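The source may hold more compounds than are shown below. What is called first, only, known or untested is meant among the compounds shown, and "the series" means these compounds.

Values measured in a functional assay on A549 cells (Homo sapiens) for cytotoxicity, read by MTT assay, with a stated time of 48 h (a lower number here means a stronger inhibitor, a higher number a weaker inhibitor), are as follows:

- Compound 1 `COc1cc(C2=NOC(c3cc(OC)c(OC)c(OC)c3)C2)ccc1O` gives 2600 nM
- Compound 2 `COc1ccc(C2=NOC(COc3ccc(-c4nnnn4-c4cc(OC)c(OC)c(OC)c4)cc3N)C2)cc1OC` gives 2520 nM
- Compound 3 `COc1cc(C2=NOC(COc3ccc(-c4nnnn4-c4cc(OC)c(OC)c(OC)c4)cc3N)C2)ccc1O` gives 2010 nM

These three values lie within the scatter of one another, so compound 3 stands level with compound 1 and compound 2 on these numbers. Going on to compound 4 `COc1cc(-n2nnnc2-c2ccc(OCC3CC(c4ccccc4F)=NO3)c(N)c2)cc(OC)c1OC`, 2-fluorophenyl takes the place of 4-hydroxy-3-methoxyphenyl on a carbon with a double bond to nitrogen. The full count of this change is 2-fluorophenyl in place of 4-hydroxy-3-methoxyphenyl on a carbon with a double bond to nitrogen and it swaps the whole group.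

Among the compounds with values here, only one measured step touches that group, a 1.3-fold lower number from compound 2 to compound 3 (0.10 log units; within the scatter), and it lies within the scatter. Within the data shown here, that step exchanges only a methyl for hydrogen on an oxygen, and no measured compound carries 2-fluorophenyl, so it is a weak guide. No step beyond the scatter is expected in this assay, though the uncertainty is wide. The expected step is a 1.2-fold higher number from compound 3 to compound 4 (0.09 log units; within the scatter) by this estimate. For compound 4 the estimated value is 2500 nM, with an expected range from 900 nM to 7000 nM around it.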

Compound 4, half-maximal inhibitory concentration: 1490 nM
Compound 4: the middle estimate sits 1.7-fold (0.22 log units) above what was measured; measured number inside the range.
By their numbers in this assay, from the lowest: compounds 4, 3, 2 and 1 (each within the scatter of the next).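

The earlier compounds shown here tested this position only by swapping a methyl for hydrogen on an oxygen, whereas compound 4 replaces the whole aromatic group on the carbon with a double bond to nitrogen. In this assay, the two steps that make this replacement, a 1.3-fold lower number from compound 3 to compound 4 (0.13 log units; within the scatter) and a 1.7-fold lower number from compound 2 to compound 4 (0.23 log units; within the scatter), both stay within the scatter, so compounds 2, 3 and 4 stand level despite carrying different groups here. 2-Fluorophenyl has no hydrogen-bond donors or acceptors, so the hydrogen-bond donor and acceptors of 4-hydroxy-3-methoxyphenyl are not needed to hold this level in these compounds, and no supporting measurement accounts for the result.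

As far as these compounds go, it remains open whether this tolerance extends to groups of another kind at this place, such as an amine, a carboxylic acid or a longer chain. From the compounds shown here alone, it also remains open whether any group here can move the number beyond the scatter.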